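The source may hold more compounds than are shown below. What is called first, only, known or untested is meant among the compounds shown, and "the series" means these compounds.

Working notes on the series. Compound 1 `C[C@@H]1CN(c2cccc3c2C[C@H](CN(C)[C@H]2CCCc4cccnc42)NC3)C[C@H](C)N1` is the starting point, tested in a functional assay on CCRF-CEM cells for agonist activity at C-X-C chemokine receptor type 4 (Homo sapiens), read by calcium flux, with a stated time of 25 min; a lower number here means that less compound is needed, a higher number that more compound is needed for the effect. In this assay compound 1 gives > 30000 nM, which is a limit of the assay and not a number. Compound 2 `c1cnc2c(c1)CCC[C@@H]2N(CC1CCCCC1)C[C@H]1Cc2c(cccc2N2CCNCC2)CN1` is the other measured member. In this assay compound 2 gives > 30000 nM, again a limit and not a number. Compound 1 therefore stands at the limit of > 30000 nM in this assay, at which 2 of the 2 values shown sit, with no numerical value to rank it against. For the measured compounds named here, no step between measured compounds is available, so no measured change can be sized. Compound 3 `CC(C)N1CCN(c2cccc3c2C[C@H](CN(C)[C@H]2CCCc4cccnc42)NC3)CC1` is not yet measured. Its change from compound 1 is 4-isopropylpiperazin-1-yl in place of 3,5-dimethylpiperazin-1-yl on an aromatic carbon. With both known values sitting at the limit, the expected step is a number no higher from compound 1 to compound 3 (the limit leaves the size open), none beyond the scatter. Compound 3 is expected at 30000 nM, within 10000 nM to 100000 nM, and is most likely to be reported again only as a limit.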

Compound 3, half-maximal effective concentration: > 30000 nM
Compound 3: a limit, no number (the forecaster's own chance of this, stated with the estimate: 80%); the middle value lies on the limit itself.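

In this assay compound 3 gives > 30000 nM, a limit and not a number. For the compounds shown here, no step between compound 1 and compound 3 can be read from this. The compounds shown leave open whether any change on the shared core gives a measurable half-maximal effective concentration in this assay.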